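This account rests on a few compounds, and the source may have more. Where it says the series, first, only, none or still open, it means among the compounds named here.

Compound 1 `COc1ccc(C(=O)c2cc(OC)c(OC)c(OC)c2)cc1NC(=O)/C=C/c1cc(OC)c(OC)c(OC)c1` gives 1200 nM in a functional assay on B16 cells (Mus musculus) for cytotoxicity, read by MTT assay, with a stated time of 72 h; a higher number here means a weaker inhibitor, a lower number a stronger inhibitor. Compound 2 `COc1cc(/C=C/C(=O)Nc2cc(C(=O)c3cc(OC)c(OC)c(OC)c3)ccc2OC)ccc1F` gives 16300 nM in this assay.

Compound 2 therefore gives the higher of the two numbers, with a 14-fold higher number from compound 1 to compound 2 (1.13 log units; beyond the scatter) separating it from compound 1. Compound 3 `COc1ccc(C(=O)c2cc(OC)c(OC)c(OC)c2)cc1NC(=O)/C=C/c1ccc(F)c(F)c1` differs from compound 2 by fluoro in place of methoxy on an aromatic carbon. Going by the values given here, only that one measured step bears on this change, and it was large when the methoxy-bearing ring was altered. Removing the remaining methoxy is expected to give a 1.5-fold higher number from compound 2 to compound 3 (0.19 log units; within the scatter) as a smaller shift in the same direction. Compound 3 is estimated at 25000 nM, within 8000 nM to 80000 nM.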

Compound 3, half-maximal inhibitory concentration: 6500 nM
Compound 3: middle estimate off by 3.8-fold (0.59 log units), on the high side, and the stated range ends above it.
By their numbers in this assay, from the lowest: compound 1; then compound 3; then compound 2.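

Putting fluoro in place of methoxy on this aromatic carbon makes the inhibitor stronger in this assay, with a 2.5-fold lower number from compound 2 to compound 3 (0.40 log units; beyond the scatter), so the methoxy of the 4-fluoro-3-methoxyphenyl group is not needed here. The 3,4-difluorophenyl group still falls short of 3,4,5-trimethoxyphenyl, with a 5.4-fold higher number from compound 1 to compound 3 (0.73 log units; beyond the scatter), so the fluoro swap recovers only part of the loss seen in compound 2. Nothing measured here gives a reason for either shift.

On these data alone, how an amine or a hydroxyl on this aromatic carbon would compare stays open.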